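Removing a methoxymethyl group: expected effect on stability

A few compounds are considered here, and "the series" means these few. Any claim that something is new, unique, unknown or untested is made for them only; others in the source may bear on it.

Compound 3 `COC[C@H]1C[C@@H](C(=O)NC[C@H]2CCCO2)CN(Cc2nc(-c3ccccc3)oc2C)C1`: 0.403 h
Compound 1 `Cc1oc(-c2ccccc2)nc1CN1CCCC(C(=O)NCC2CCOCC2)C1`: 0.156 h
Compound 2 `Cc1cccc(CNC(=O)[C@H]2C[C@H](c3nc(C)no3)CN(Cc3nc(-c4ccccc4)oc3C)C2)n1`: < 0.05 h, a limit of the assay rather than a number

In an in vitro ADME assay on microsomes from liver (Homo sapiens) for metabolic stability (a lower number here means that the compound disappears faster, a higher number that the compound lasts longer), compound 3 gives the highest of the two numbers, with compound 1 lower by a gap beyond the usual scatter. Compound 2 sits at the limit of < 0.05 h in this assay, at which 1 of the 3 values shown sits. Compound 4 `Cc1oc(-c2ccccc2)nc1CN1CCC[C@@H](C(=O)NC[C@H]2CCCO2)C1` has not yet been measured; it differs from compound 3 by hydrogen in place of methoxymethyl on a saturated ring carbon. Among the compounds with values here, no measured pair isolates this change, since compound 1 lacks the methoxymethyl but also carries a different amide. The step from compound 3 to compound 4 is expected to be a modest drop, a 2.0-fold lower number from compound 3 to compound 4 (0.30 log units; within the scatter), roughly toward compound 1. Compound 4 is therefore estimated at 0.2 h, between 0.08 h and 0.5 h.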

Compound 4, half-life: 0.193 h
Beside the measured number, compound 4's estimate is 1.0-fold (0.02 log units) above it; the range from low to high includes it.
By their numbers in this assay, from the lowest: compounds 1 and 4 (each within the scatter of the next); then compound 3. At a limit, below all of these: compound 2.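

In this assay, within the data shown here, this pair gives the first clean reading of this ring carbon. Only the substituent changes, while the ((oxolan-2-yl)methyl)carbamoyl group stays in place. Putting hydrogen in place of methoxymethyl gives a 2.1-fold lower number from compound 3 to compound 4 (0.32 log units; beyond the scatter), so the compound with methoxymethyl lasts longer, by a modest margin. Nothing shown explains why this happens. On these data alone, it remains open whether the ether oxygen matters or simply the presence of a chain here. A methyl, ethyl or hydroxymethyl group on this ring carbon would help separate those possibilities.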